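Notes on the benzofuran-linked series: compound 4 forecast

The source may report more compounds than this note shows. Statements on the series, on what has been measured and on what is new or still open speak of the compounds shown alone.

Measured so far:
- compound 1 `COc1cc(OCc2ccccc2OC)c2cc(-c3cn4nc(OC)sc4n3)oc2c1`: 19 nM
- compound 2 `COc1cc(OCc2cccc(O)c2)c2cc(-c3cn4nc(OC)sc4n3)oc2c1`: 3.1 nM
- compound 3 `COc1cc(OCc2cccc(Sc3ccccc3)c2)c2cc(-c3cn4nc(OC)sc4n3)oc2c1`: 0.89 nM

In a functional assay on HEK293 cells for antagonist activity at proteinase-activated receptor 4 (Homo sapiens), read by FLIPR and calcium flux, with a stated time of 30 min (on this read-out higher numbers stand for weaker inhibition and lower numbers for stronger inhibition), compound 3 holds the lowest number of the three, with compound 2 nearest and compound 1 furthest; both gaps lie beyond the scatter, the steps being a 6.1-fold lower number from compound 1 to compound 2 (0.79 log units; beyond the scatter) and a 3.5-fold lower number from compound 2 to compound 3 (0.54 log units; beyond the scatter).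

Compound 4 `COc1cc(OCc2cccc(C#N)c2)c2cc(-c3cn4nc(OC)sc4n3)oc2c1` differs from compound 3 by cyano in place of phenylsulfanyl on an aromatic carbon. Among the compounds with values here, the one step that touches this position is the move from compound 2 to compound 3, a 3.5-fold lower number from compound 2 to compound 3 (0.54 log units; beyond the scatter), where a larger group at that carbon went with a lower number. The step from compound 1 to compound 2 changed a different carbon and bears on it only loosely. A cyano group is small, closer in size to hydroxy than to phenylsulfanyl, so a number somewhat above compound 3 is expected, near compound 2. The estimated step is a 4.5-fold higher number from compound 3 to compound 4 (0.65 log units; beyond the scatter).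

For compound 4 the expected value in this assay is 4 nM, with a range from 1.5 nM to 12 nM.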

Compound 4, half-maximal inhibitory concentration: 0.98 nM
For compound 4 the middle estimate is 4.1-fold (0.61 log units) above the measured one; the measured number lies below the stated range.
By their numbers in this assay, from the lowest: compounds 3 and 4 (each within the scatter of the next); then compound 2; then compound 1.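

In this assay, the link between a larger group at this aromatic carbon and a lower number does not hold for compound 4, as the far smaller cyano shows a 1.1-fold higher number from compound 3 to compound 4 (0.04 log units; within the scatter). Cyano in place of hydroxy gives a 3.2-fold lower number from compound 2 to compound 4 (0.50 log units; beyond the scatter), and 3-cyanophenyl in place of 2-methoxyphenyl gives a 19-fold lower number from compound 1 to compound 4 (1.29 log units; beyond the scatter). No supporting data explain why these two different groups give numbers within the scatter of each other.

Still open, going by these compounds, is whether an amine or a carboxylic acid on this aromatic carbon would give a number close to those of compound 3 and compound 4.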